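The source may hold more compounds than are shown below. What is called first, only, known or untested is meant among the compounds shown, and "the series" means these compounds.

Compound 1 `COc1cc(/C=C/C=O)cc(OC)c1OC/C=C(\C)CCC=C(C)C` gives 26000 nM
Compound 2 `COc1cc(/C=C/C=O)ccc1OC/C=C(\C)CCC=C(C)C` gives 28000 nM

In a functional assay on SK-MEL-28 cells (Homo sapiens) for cytotoxicity, read by MTT assay, with a stated time of 72 h (a higher number here means a weaker inhibitor, a lower number a stronger inhibitor), compound 2 stands at 28000 nM and is level with compound 1 within the scatter. Compound 3 `COc1cc(/C=C/CO)ccc1OC/C=C(\C)CCC=C(C)C` carries one change from compound 2: hydroxymethyl in place of formyl on a double-bonded chain carbon bound to a double-bonded chain carbon. For the measured compounds named here, the only measured step, a 1.1-fold higher number from compound 1 to compound 2 (0.03 log units; within the scatter), puts hydrogen in place of methoxy on an aromatic carbon and so only loosely bears on this change. Going by the values given here, no measured step covers hydroxymethyl in place of formyl, so in this assay no shift beyond the scatter is expected. The expected change is a 1.3-fold higher number from compound 2 to compound 3 (0.10 log units; within the scatter). Compound 3 is estimated at 35000 nM, with a range of 14000 nM to 90000 nM.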

Compound 3, half-maximal inhibitory concentration: 31000 nM
Compound 3: the middle estimate sits 1.1-fold (0.05 log units) above what was measured; the measured number falls inside the stated range.
By their numbers in this assay, from the lowest: compounds 1, 2 and 3 (each within the scatter of the next).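

Placing hydroxymethyl in place of formyl on a double-bonded chain carbon bound to a double-bonded chain carbon gives a 1.1-fold higher number from compound 2 to compound 3 (0.04 log units; within the scatter) in this assay. The earlier compounds shown here showed only a change on an aromatic carbon, whereas this pair shows that the number also holds level when this chain end changes, even though the entering group brings a hydrogen-bond donor that formyl lacks. No available evidence bears on this result. Going by these compounds, whether a carboxylic acid or an amine at this place would move the number beyond the scatter stays open.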